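Amide substituent changes on a vitamin D receptor agonist series

The source may report more compounds than this note shows. Statements on the series, on what has been measured and on what is new or still open speak of the compounds shown alone.

Of the compounds shown here, two have been measured in an assay on cells for agonist activity at vitamin D3 receptor (Homo sapiens), with a stated time of 96 h; a lower number here means that less compound is needed, a higher number that more compound is needed for the effect. Compound 1 `CCn1c(C(=O)NCC#N)ccc1C(CC)(CC)c1ccc(OCCC(O)(CC)CC)c(C)c1` gives 1080 nM. Compound 2 `CCOc1ccc(NC(=O)c2ccc(C(CC)(CC)c3ccc(OCCC(O)(CC)CC)c(C)c3)n2CC)cc1` gives 1630 nM in this assay. Compound 2 carries the higher of the two numbers, yet the step of a 1.5-fold higher number from compound 1 to compound 2 (0.18 log units; within the scatter) lies within the scatter, so the two compounds cannot be ordered on these data.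

Compound 3 `CCOC(=O)CN(C)C(=O)c1ccc(C(CC)(CC)c2ccc(OCCC(O)(CC)CC)c(C)c2)n1CC` has not yet been measured. It differs from compound 2 as follows: ((ethoxycarbonyl)methyl)(methyl)amino in place of (4-ethoxyphenyl)amino on a carbonyl carbon. Among the measured compounds shown here, the one measured step that bears on this is the exchange on the same amide-type nitrogen, a 1.5-fold higher number from compound 1 to compound 2 (0.18 log units; within the scatter), which shows that a large change of the group on that nitrogen left the number within the scatter. For the measured compounds named here, compound 3 additionally lacks the amide hydrogen, for which no measured step exists, so the data give no ground to expect a move beyond the scatter in either direction. The expected step is therefore a 1.2-fold lower number from compound 2 to compound 3 (0.07 log units; within the scatter). Compound 3 is estimated at 1400 nM in this assay, with a range from 450 nM to 4500 nM.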

Compound 3, half-maximal effective concentration: 520 nM
Beside the measured number, compound 3's estimate is 2.7-fold (0.43 log units) above it; the measured number falls inside the stated range.
By their numbers in this assay, from the lowest: compound 3; then compounds 1 and 2 (each within the scatter of the next).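

In this assay, the step to ((ethoxycarbonyl)methyl)(methyl)amino on a carbonyl carbon gives a 3.1-fold lower number from compound 2 to compound 3 (0.50 log units; beyond the scatter) and, taken from the cyanomethyl amide, a 2.1-fold lower number from compound 1 to compound 3 (0.32 log units; beyond the scatter), so both steps lie beyond the scatter, though only modestly. Among the compounds shown here, the earlier exchange on this nitrogen, a 1.5-fold higher number from compound 1 to compound 2 (0.18 log units; within the scatter), stayed within the scatter, so this position can move the number after all, and compound 3 is the only one of the three with a lower number than the others, as well as the only one without the amide hydrogen and the only one with an ethoxycarbonyl group. Nothing at hand explains why the number falls with this change.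

The compounds shown leave open whether the lower number follows the methyl on the amide nitrogen or the ethoxycarbonyl group, as compound 3 introduces both in a single exchange. A plain dimethylamino group on the same carbonyl carbon would separate the two, and a carboxylic acid in place of the ethyl ester would show how much the ester itself counts.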